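The source may report more compounds than this note shows. Statements on the series, on what has been measured and on what is new or still open speak of the compounds shown alone.

Measured so far in an ADME assay on cells (Hepatocyte, Rattus norvegicus, strain Wistar) for pharmacokinetics, read by LC-MS, with a stated time of 90 min, tested at 1 uM; a higher number here means faster removal of the compound, a lower number slower removal:
- compound 1 `COc1cc(C(=O)N2CCC(O)CC2)cc2nc(NCc3cccc(Cl)c3)oc12`: 21.7 mL/min/kg
- compound 2 `COc1cc(C(=O)N2CC[C@@H](O)[C@H](C)C2)cc2nc(NCc3cccc(Cl)c3)oc12`: 38.3 mL/min/kg

Within the data shown here, compound 2 stands at 38.3 mL/min/kg, within the scatter of compound 1, its only neighbour so far. Compound 3 `COc1cc(C(=O)N2CC(C)C(O)CC2C)cc2nc(NCc3cccc(Cl)c3)oc12` differs from compound 2 by 4-hydroxy-2,5-dimethylpiperidin-1-yl in place of 4-hydroxy-3-methylpiperidin-1-yl on a carbonyl carbon, with 4-hydroxy-2,5-dimethylpiperidin-1-yl in place of 4-hydroxy-3-methylpiperidin-1-yl on a carbonyl carbon.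

Among the measured compounds shown here, one measured step bears on this change: a 1.8-fold higher number from compound 1 to compound 2 (0.25 log units; within the scatter), where methyl takes the place of hydrogen on a saturated ring carbon. One step sets no trend, and this one does not leave the scatter. From the compounds shown here alone, no step beyond the scatter is therefore expected in this assay, and the direction stays open. The expected step is a 1.1-fold higher number from compound 2 to compound 3 (0.04 log units; within the scatter). For compound 3 the estimate is 42 mL/min/kg, with an expected range of 22 mL/min/kg to 75 mL/min/kg.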

Compound 3, clearance: 56.7 mL/min/kg
The estimate for compound 3 lay 1.4-fold (0.13 log units) below the measured number; the measured number falls inside the stated range.
By their numbers in this assay, from the lowest: compounds 1, 2 and 3 (each within the scatter of the next, the first and the last beyond it).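

In this assay, among these compounds, the replacement of 4-hydroxypiperidin-1-yl by 4-hydroxy-2,5-dimethylpiperidin-1-yl on the carbonyl carbon gives the first step beyond the scatter, a 2.6-fold higher number from compound 1 to compound 3 (0.42 log units; beyond the scatter), although a modest one. The replacement of 4-hydroxy-3-methylpiperidin-1-yl by the same group stays within the scatter, at a 1.5-fold higher number from compound 2 to compound 3 (0.17 log units; within the scatter), so only the two end compounds of this short set separate. Nothing measured here explains the difference.

Which of the two methyl groups in 4-hydroxy-2,5-dimethylpiperidin-1-yl accounts for the larger step remains open, as does the comparison of its stereoisomers, for the group is given without defined stereocentres. Also open, from the compounds shown here alone, is how an amine or a carboxylic acid in place of the hydroxyl group would read in this assay.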